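The source may hold more compounds than are shown below. What is called first, only, known or untested is meant among the compounds shown, and "the series" means these compounds.

Measured compounds:

Compound 1 `O=C(NO)c1ccc(CN2C(=O)CN(Cc3ccc(Cl)cc3)C2=O)cc1` — 8.3 nM
Compound 2 `Cc1ccc(CN2CC(=O)N(Cc3ccc(C(=O)NO)cc3)C2=O)cc1` — 17.6 nM
Compound 3 `O=C(NO)c1ccc(CN2C(=O)NC(Cc3ccc(Cl)cc3)(c3ccccc3)C2=O)cc1` — 54 nM

The three compounds were tested in an assay on isolated protein for inhibition of protein deacetylase HDAC6 (Homo sapiens), read by fluorescence, with stated times of 10 min and 2 h; a lower number here means a stronger inhibitor, a higher number a weaker inhibitor. Compound 1 gives 8.3 nM, and compound 2 gives 17.6 nM. The two share one core and differ in a single place: methyl in place of chloro on an aromatic carbon. This change produced a 2.1-fold higher number from compound 1 to compound 2 (0.33 log units; beyond the scatter).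

Compound 3 sits on a different core, and the difference between the two cores is not broken down here. In this assay compound 3 gives 54 nM, the highest of the three numbers; its nearest neighbour is compound 2, and it stands furthest from compound 1.

Compound 4 `Cc1ccc(CC2(c3ccccc3)NC(=O)N(Cc3ccc(C(=O)NO)cc3)C2=O)cc1` has not yet been measured. It is related to compound 3 exactly as compound 2 is related to compound 1: methyl in place of chloro on an aromatic carbon. The place of the change is the same in both pairs, so this is the same change made on the second core.

Among the compounds with values here, the expectation for compound 4 rests on the only measured instance of this change, the step from compound 1 to compound 2 of a 2.1-fold higher number from compound 1 to compound 2 (0.33 log units; beyond the scatter). Carried over to the second core, the change is expected to give a step of about a 2.0-fold higher number from compound 3 to compound 4 (0.31 log units; beyond the scatter), since nothing measured suggests the two cores respond differently. Compound 4 is therefore estimated at 110 nM, with a plausible range from 55 nM to 250 nM.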

Compound 4, half-maximal inhibitory concentration: 82.4 nM
Compound 4: middle estimate off by 1.3-fold (0.13 log units), on the high side; measured number inside the range.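

On the core of compound 3, methyl in place of chloro gives a 1.5-fold higher number from compound 3 to compound 4 (0.18 log units; within the scatter) in this assay, so on this core the change stays inside what repeated measurements would be expected to show. Set beside the step on the core of compound 1, the change reads alike on both cores, with the two steps not separable from each other: the same change on two cores in this assay, a 2.1-fold higher number (0.33 log units; beyond the scatter) from compound 1 to compound 2 and a 1.5-fold higher number (0.18 log units; within the scatter) from compound 3 to compound 4, 1.4-fold (0.14 log units) apart, within the scatter of two such steps. Within the data shown here, this supports carrying this one change across these two cores as a small effect of similar size, but it rests on only two pairs in a single assay, so it does not show that the agreement would hold on any other core, and it does not explain why the change behaves as it does.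

The compounds shown carry only chloro or methyl at this place on the aromatic ring, so it remains open how a fluoro, a methoxy, a nitrile or an amine there would read on either core. As far as these compounds go, it also remains open whether the two cores would still respond alike to a larger change, such as a longer chain in place of the 4-chlorobenzyl group.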